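A chloro step from an inactive compound

The compounds below may be only part of what the source reports. "The series", "measured", "known", "first", "only" and "open" are said of these compounds alone.

So far three compounds have been read in a functional assay on Bel-7402 cells (Homo sapiens) for inhibition, read by MTT assay, with a stated time of 24 h, tested at 10 ug/mL (on this read-out higher numbers stand for more inhibition of growth at the one concentration tested and lower numbers for less inhibition of growth), and their results differ in kind. Compound 1 (`O=C(CCCCC(S)CCS)NO`) gives 28.2% in this test, while compound 2 (`O=C(CCCCC1CCSS1)Nc1ccc(Cl)cn1`) gives 16.1% in the same test. Compound 3 (`O=C(CCCCC(S)CCS)Nc1ccccn1`) stands apart: it is recorded as "not active" (no number reported) and carries no single number, so no figure ranks it against the other two.

Compound 4 (`O=C(CCCCC(S)CCS)Nc1ccc(Cl)cn1`) is still to be measured. Going by the values given here, the one structural change is chloro in place of hydrogen on an aromatic carbon with chloro in place of hydrogen on an aromatic carbon, two atoms from the ring nitrogen and para to a large group. Among the compounds with values here, no measured pair shows what this change does, so any forecast rests on little. In this assay a small upward step is expected, of about the size of the usual scatter, starting from a compound without a figure. Within the data shown here, the only measured compound bearing chloro is compound 2 at 16.1% and that value serves as the anchor for the expectation. A report without a number, like that for compound 3, also remains possible. For compound 4 the estimated inhibition is 15% with an expected range from 3% to 32% as working figures.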

Compound 4, percent growth inhibition at one concentration: 17.8%
For compound 4 the middle estimate is 2.8 percentage points below the measured one; low and high end bracket the measured number.
By their numbers in this assay, from the lowest: compounds 2 and 4 (each within the scatter of the next); then compound 1.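

In this assay compound 4 carries a number, whereas compound 3 is recorded as "not active" (no number reported). Chloro in place of hydrogen on this aromatic carbon, two atoms from the ring nitrogen and para to a large group, therefore separates a reported figure from a report without one, though the size of that change cannot be read. With chloro present, a group of 5 heavy atoms (3 carbon, 2 sulfur; no ring) in place of the group holding the five-membered non-aromatic ring gives a number 1.7 percentage points higher from compound 2 to compound 4 (within the scatter), so these two groups cannot be told apart on this read-out, and nothing available bears on the reason for either result.

On these data alone, whether bromo, methyl or an amine on the same aromatic carbon would also give a reported figure remains open, as does whether the chloro result depends on this exact place on the ring. The compounds shown also leave open what a longer chain between the carbonyl and the sulfur-bearing group would do, and how the ring-containing group behaves with hydrogen in place of chloro.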